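Trimming an Amine Tail on a Dialkylated Aminoglycoside Fragment

The compounds below may be only part of what the source reports. "The series", "measured", "known", "first", "only" and "open" are said of these compounds alone.

Three compounds have been examined in a toxicity assay on the whole organism (J774 cells) for cytotoxicity, with Mus musculus as the target, read by MTT assay, with a stated time of 24 h, tested at 30 uM; a higher number here means a weaker effect of the compound at the concentration tested, a lower number a stronger effect. Compound 1, `CCCCCCCCCO[C@@H]1[C@@H](N)[C@@H](O[C@H]2[C@H](O)[C@@H](OCCCCCCCCC)[C@H](N)C[C@@H]2N)O[C@H](CN)[C@H]1O`, carries a single nonyl chain and a second amino sugar; in this assay compound 1 gives 38.8%. Compound 3, `NC[C@H]1O[C@H](O[C@H]2[C@H](O)[C@@H](O)[C@H](N)C[C@@H]2N)[C@H](N)[C@@H](OCCCc2ccc3ccccc3c2)[C@@H]1OCCCc1ccc2ccccc2c1`, bears two naphthylpropyl chains and gives 66.9%. Compound 2, `CCCCCCCCCO[C@@H]1[C@@H](N)[C@@H](OCC(O)CNCCCO)O[C@H](CN)[C@H]1OCCCCCCCCC`, has two nonyl chains and an open side arm ending in a secondary amine; in this assay compound 2 gives 13.7%, the lowest of the three numbers and therefore the strongest effect, with compound 1 the nearest neighbour and compound 3 the furthest, both separated from it by more than the usual scatter.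

Compound 4, `CCCCCCCCCO[C@@H]1[C@@H](N)[C@@H](OC[C@@H](O)CN)O[C@H](CN)[C@H]1OCCCCCCCCC`, keeps both nonyl chains and the same core but shortens the side arm: 2-amino-1-hydroxyethyl in place of 1-hydroxy-2-((3-hydroxypropyl)amino)ethyl on a saturated chain carbon bound to an oxygen on a saturated carbon. Within the data shown here, no pair of measured compounds shows this kind of change, so nothing in the data fixes its size. The shared dialkylated core is retained, and the change removes only part of the open arm, so the expected step is small, leaning slightly toward a higher number: a number 8.3 percentage points higher from compound 2 to compound 4 (within the scatter) is estimated to lie close to the scatter. Compound 4 is therefore expected to give about 22% in this assay, somewhere between 8% and 45%.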

Compound 4, a percentage reported as activity, at one concentration (the size of the read-out at that concentration, not a potency): 7.2%
Compound 4: the middle estimate sits 14.8 percentage points above what was measured; measured number below the stated range.
By their numbers in this assay, from the lowest: compounds 4 and 2 (each within the scatter of the next); then compound 1; then compound 3.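

Among these compounds, putting 2-amino-1-hydroxyethyl in place of 1-hydroxy-2-((3-hydroxypropyl)amino)ethyl on a saturated chain carbon bound to an oxygen on a saturated carbon gives in this assay the first step that can be read from a single change: a number 6.5 percentage points lower from compound 2 to compound 4 (within the scatter). With both nonyl chains and the shared core held fixed, compound 2 and compound 4 cannot be told apart here, so the 3-hydroxypropyl end of the arm is not needed for a reading at this level, although this one pair cannot separate the shorter arm from the defined stereocentre that enters with it. No measurement shown here explains this result.

The compounds shown do not say how an arm ending in a carboxylic acid or a tertiary amine, or one carrying a longer chain, would read at this position. They also leave open whether the same trimming would read alike on a core carrying hexyl chains or the naphthylpropyl chains of compound 3 in place of the two nonyl chains.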